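Working notes on the amide series: an estimate for compound 4

The source may hold more compounds than are shown below. What is called first, only, known or untested is meant among the compounds shown, and "the series" means these compounds.

Measured in a functional assay for agonist activity at 5-hydroxytryptamine receptor 4 (Homo sapiens), read by cAMP accumulation; on this read-out lower numbers stand for an effect already at smaller amounts and higher numbers for an effect only at larger amounts of compound:
- compound 1 `CS(=O)(=O)N1CCN(CC(O)CN2CCC(NC(=O)c3cccc4[nH]cnc34)CC2)CC1`: 631 nM
- compound 2 `CC(C)(C)c1nc2c(C(=O)NCC3CCN(CC(O)CN4CCN(S(C)(=O)=O)CC4)CC3)cccc2[nH]1`: 3.16 nM
- compound 3 `COC(=O)N1CCN(CCN2CCC(CNC(=O)c3cccc4[nH]c(C(C)C)nc34)CC2)CC1`: 1.59 nM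

Compound 3 gives the lowest of the three numbers; compound 2 sits within the scatter of it, while compound 1 lies far beyond the scatter on the higher side. Compound 4 `CC(=O)N1CCC(CN2CCC(CNC(=O)c3cccc4[nH]c(C(C)C)nc34)CC2)CC1` differs from compound 3 in one place: 1-acetylpiperidin-4-yl in place of (4-(methoxycarbonyl)piperazin-1-yl)methyl on a saturated chain carbon bound to an amine nitrogen in a ring. For the measured compounds named here, no measured pair isolates this change, so its direction is uncertain. Given that compound 2 and compound 3 agree closely despite different tails on this end, the expected step of a 2.0-fold higher number from compound 3 to compound 4 (0.30 log units; within the scatter) is small, at most within the scatter, possibly slightly toward higher numbers. Compound 4 is estimated at 3.2 nM, with a range from 1 nM to 12 nM in this assay.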

Compound 4, half-maximal effective concentration: 1.59 nM
The estimate for compound 4 lay 2.0-fold (0.30 log units) above the measured number, within the range that was stated.
By their numbers in this assay, from the lowest: compounds 3, 4 and 2 (each within the scatter of the next); then compound 1.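

In this assay, placing 1-acetylpiperidin-4-yl in place of (4-(methoxycarbonyl)piperazin-1-yl)methyl on a saturated chain carbon bound to an amine nitrogen in a ring gives no change at the digits printed from compound 3 to compound 4 (within the scatter). For the compounds shown here, this is the first direct reading of a change at this position, and it shows that the second ring nitrogen and the methoxycarbonyl group of compound 3 are not needed to keep this number. No supporting data bear on a cause for this result. On these data alone, whether a carboxylic acid or a free amine at this place would leave the number unchanged stays open. A longer chain between the two rings is equally unresolved.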